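A few compounds are considered here, and "the series" means these few. Any claim that something is new, unique, unknown or untested is made for them only; others in the source may bear on it.

Measured in a functional assay on MCF7 cells (Homo sapiens) for cytotoxicity, read by MTT assay, with a stated time of 24 h; a higher number here means a weaker inhibitor, a lower number a stronger inhibitor:
- compound 1 `Cn1c(-c2ccc(NC(=O)CCl)cc2)nc(-c2ccccc2)c1-c1ccccc1`, gives 42.6 ug/mL
- compound 2 `Cn1nnnc1SCC(=O)Nc1ccc(-c2nc(-c3ccccc3)c(-c3ccccc3)n2C)cc1`, gives 4.5 ug/mL
- compound 3 `CN(C)/C=C/N1CCN(CC(=O)Nc2ccc(-c3nc(-c4ccccc4)c(-c4ccccc4)n3C)cc2)CC1`, gives 80 ug/mL

Compound 3 has the highest number of the three. The gap to compound 1 is small, a 1.9-fold higher number from compound 1 to compound 3 (0.27 log units; within the scatter), so the two cannot be ranked against each other; the gap to compound 2 is wide, an 18-fold higher number from compound 2 to compound 3 (1.25 log units; beyond the scatter).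

Compound 4 `Cn1c(-c2ccc(NC(=O)CN3CCN(Cc4ccccc4)CC3)cc2)nc(-c2ccccc2)c1-c1ccccc1` differs from compound 3 in one place: benzyl in place of 2-(dimethylamino)ethenyl on an amine nitrogen in a ring. Among the measured compounds shown here, none of the measured steps touches this place; all three of them swap the group on the saturated chain carbon bound to the carbonyl carbon, and they range from within the scatter, as in a 1.9-fold higher number from compound 1 to compound 3 (0.27 log units; within the scatter), to large, as in an 18-fold higher number from compound 2 to compound 3 (1.25 log units; beyond the scatter). For the measured compounds named here, the only guide is therefore the spread of the numbers already seen, which leaves the direction open. For compound 4 the expected value in this assay is 50 ug/mL, with a likely range from 15 ug/mL to 160 ug/mL. The estimated step of a 1.6-fold lower number from compound 3 to compound 4 (0.20 log units; within the scatter) is thus small and uncertain.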

Compound 4, half-maximal inhibitory concentration: 80 ug/mL
Compound 4: the middle estimate sits 1.6-fold (0.20 log units) below what was measured; measured number inside the range.
By their numbers in this assay, from the lowest: compound 2; then compounds 1, 3 and 4 (each within the scatter of the next).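

In this assay, among the compounds shown here, benzyl in place of 2-(dimethylamino)ethenyl on an amine nitrogen in a ring gives no change at the digits printed from compound 3 to compound 4 (within the scatter), the first reading of a change at this position. The entering group has a six-membered aromatic ring of carbon only and no hydrogen-bond acceptor, while the leaving group has no ring, a double bond outside aromatic rings and a hydrogen-bond acceptor, yet this pair shows no separation between them. No measurement offered here explains why these two groups read alike.

Going by these compounds, with only these two groups at this nitrogen, it remains open whether the position is generally insensitive or the pair simply happens to match. A methyl, an acetyl or a carboxylic acid on a short chain at this nitrogen, or a fluorine or methoxy on the benzyl ring, could still shift the number.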